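The source may hold more compounds than are shown below. What is called first, only, known or untested is meant among the compounds shown, and "the series" means these compounds.

Measured so far in a physicochemical assay for solubility, read by HPLC, with a stated time of 4 h, at pH 1; on this read-out higher numbers stand for higher solubility and lower numbers for lower solubility:
- compound 1 `COc1ccc2c(c1)c(CC(=O)OCOC(=O)OC(C)C)c(C)n2C(=O)c1ccc(Cl)cc1`, giving 0.119 ug/mL
- compound 2 `COc1ccc2c(c1)c(CC(=O)OCCOC(C)=O)c(C)n2C(=O)c1ccc(Cl)cc1`, giving 0.111 ug/mL

Compound 2 holds the lowest of the two numbers in this assay, with compound 1 nearest; the step of a 1.1-fold lower number from compound 1 to compound 2 (0.03 log units; within the scatter) lies within the scatter. Compound 3 `COc1ccc2c(c1)c(CC(=O)OCc1oc(=O)oc1C)c(C)n2C(=O)c1ccc(Cl)cc1` is not yet measured. Its change from compound 2 is a group of 7 heavy atoms (4 carbon, 3 oxygen; one five-membered aromatic ring with 2 hetero atoms) in place of a group of 5 heavy atoms (3 carbon, 2 oxygen; no ring), on a saturated chain carbon bound to an oxygen next to a carbonyl group. For the measured compounds named here, the only step at this position, a 1.1-fold lower number from compound 1 to compound 2 (0.03 log units; within the scatter), was within the scatter, and it is the sole bearing on the new change; no step exchanges an open-chain group for a ring-bearing one here. A step of a 1.0-fold lower number from compound 2 to compound 3 (0.00 log units; within the scatter) is therefore expected, none beyond the scatter. Compound 3 is estimated at 0.11 ug/mL, within 0.04 ug/mL to 0.33 ug/mL.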

Compound 3, solubility: 0.0638 ug/mL
Estimate against measurement, compound 3: 1.7-fold (0.24 log units) above, and the stated range covers the measured number.
By their numbers in this assay, from the lowest: compounds 3, 2 and 1 (each within the scatter of the next).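

In this assay, for the compounds shown here, the first exchange of an open-chain group for one five-membered aromatic ring with 2 hetero atoms, on a saturated chain carbon bound to an oxygen next to a carbonyl group, gives a 1.7-fold lower number from compound 2 to compound 3 (0.24 log units; within the scatter) and a 1.9-fold lower number from compound 1 to compound 3 (0.27 log units; within the scatter) against the two open-chain groups. Ring-bearing and open-chain groups at this place therefore remain within the scatter of each other in this series. Still open, going by these compounds, is whether an amine, a carboxylic acid or a longer chain at this place would give a step beyond the scatter. No measurement on hand accounts for these steps.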